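A few compounds are considered here, and "the series" means these few. Any claim that something is new, unique, unknown or untested is made for them only; others in the source may bear on it.

Compound 3 `O=C1c2c[n+]([O-])c3ccccc3c2C(=O)c2c1c1ccccc1n2Cc1cn(CC(O)CO)nn1` is one of three close analogues built on a shared core and tested in a functional assay on MDA-MB-231 cells (Homo sapiens) for cytotoxicity, read by MTT assay, with a stated time of 72 h; a lower number here means a stronger inhibitor, a higher number a weaker inhibitor. Compound 3 gives 1290 nM. Compound 1 `CN1CCN(CCCCCn2c3c(c4ccccc42)C(=O)c2c[n+]([O-])c4ccccc4c2C3=O)CC1` gives 2270 nM, and compound 2 `CC1(C)O[C@@H](CO)[C@H](Cn2cc(Cn3c4c(c5ccccc53)C(=O)c3c[n+]([O-])c5ccccc5c3C4=O)nn2)O1` gives 680 nM. The number for compound 3 lies between the other two, and neither gap sets it apart: the step of a 1.8-fold lower number from compound 1 to compound 3 (0.25 log units; within the scatter) and the step of a 1.9-fold higher number from compound 2 to compound 3 (0.28 log units; within the scatter) both stay within the scatter, so on these numbers the three compounds cannot be told apart.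

Compound 4 `CC1(C)OC[C@H](Cn2cc(Cn3c4c(c5ccccc53)C(=O)c3c[n+]([O-])c5ccccc5c3C4=O)nn2)O1` has not yet been measured. It differs from compound 3 in one place: 2,2-dimethyl-1,3-dioxolan-4-yl in place of 1,2-dihydroxyethyl on a saturated chain carbon bound to an aromatic nitrogen. The closest guide is a 1.9-fold higher number from compound 2 to compound 3 (0.28 log units; within the scatter), a change in which a 5-(hydroxymethyl)-2,2-dimethyl-1,3-dioxolan-4-yl gave way to 1,2-dihydroxyethyl. The change to compound 4 runs the other way, restoring a 2,2-dimethyl-1,3-dioxolan-4-yl, though now without the hydroxymethyl. The other step, a 1.8-fold lower number from compound 1 to compound 3 (0.25 log units; within the scatter), touches a different group and offers little guidance. Compound 4 is expected to show a step of a 1.5-fold lower number from compound 3 to compound 4 (0.18 log units; within the scatter), a small move toward a lower number that is not expected to go beyond the scatter. Compound 4 is expected to give 850 nM, within a range from 350 nM to 2000 nM.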

Compound 4, half-maximal inhibitory concentration: 530 nM
Estimate against measurement, compound 4: 1.6-fold (0.21 log units) above; the range from low to high includes it.
By their numbers in this assay, from the lowest: compounds 4, 2, 3 and 1 (each within the scatter of the next, the first and the last beyond it).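

In this assay, among the compounds shown here, putting 2,2-dimethyl-1,3-dioxolan-4-yl in place of 1,2-dihydroxyethyl on a saturated chain carbon bound to an aromatic nitrogen gives a 2.4-fold lower number from compound 3 to compound 4 (0.39 log units; beyond the scatter) and is the first single change in this small set to exceed the usual scatter, so this position does respond to some change, if only modestly. The hydroxymethyl on the ring adds no readable effect: hydrogen in its place gives a 1.3-fold lower number from compound 2 to compound 4 (0.11 log units; within the scatter), so the two ring-bearing compounds cannot be told apart. Nothing in the available data explains why the ring form gives the lower number.

Going by these compounds, it remains open whether the step depends on the closed ring itself, on the two methyl groups, or on replacing the two free hydroxyl groups, and a methoxy ether or an unsubstituted 1,3-dioxolane ring at this position could help separate these possibilities. On these data alone, it is also open how the mirror-image form of the 2,2-dimethyl-1,3-dioxolan-4-yl group, or a chain ending in an amine or a carboxylic acid, would behave here.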